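The compounds below may be only part of what the source reports. "The series", "measured", "known", "first", "only" and "open" are said of these compounds alone.

Compound 1 `O=C(CCCCC1CCSS1)Nc1ccc(Br)cn1` gives 45.5%
Compound 2 `O=C(CCCCC(S)CCS)Nc1ccccn1` gives 3.62%
Compound 3 `O=C(CCCCC(S)CCS)Nc1ccc(Cl)cn1` gives 50.7%

In a functional assay on Bel-7402 cells (Homo sapiens) for inhibition, read by MTT assay, with a stated time of 24 h, tested at 100 ug/mL (on this read-out lower numbers stand for less inhibition of growth and higher numbers for more inhibition of growth at the one concentration tested), compound 3 stands at 50.7% on this scale. Compound 1 at 45.5% lies within the scatter of it, while compound 2 at 3.62% lies far beyond the scatter below it. The next compound is compound 4 `O=C(CCCCC(S)CCS)Nc1ccc(Br)cn1` with the change bromo in place of chloro on an aromatic carbon that puts bromo in place of chloro on an aromatic carbon. Within the data shown here, one measured step bears on this place, and it is large: a number 47.1 percentage points higher from compound 2 to compound 3 (beyond the scatter) for chloro in place of hydrogen. Among the measured compounds shown here, that step does not compare chloro with bromo, and no measured pair does. Compound 1 also carries bromo, on a different chain, and its 45.5% is within the scatter of compound 3. In this assay no step beyond the scatter is therefore expected. The estimated step is a number 0.7 percentage points lower from compound 3 to compound 4 (within the scatter) and this stays within the scatter. For compound 4 the expected value is 50% in an estimated range from 35% to 65% for this measurement.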

Compound 4, percent growth inhibition at one concentration: 41.2%
For compound 4 the middle estimate is 8.8 percentage points above the measured one; the range from low to high includes it.
By their numbers in this assay, from the lowest: compound 2; then compounds 4, 1 and 3 (each within the scatter of the next).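

In this assay, bromo and chloro on this aromatic carbon, two atoms from the ring nitrogen, cannot be told apart, with a number 9.5 percentage points lower from compound 3 to compound 4 (within the scatter). Bromo in place of hydrogen at the same carbon gives a number 37.6 percentage points higher from compound 2 to compound 4 (beyond the scatter), so the large rise is not confined to chloro but is seen with both halogens. With bromo held fixed, the open chain with its two sulfur atoms and the five-membered ring of compound 1 also cannot be told apart, with a number 4.3 percentage points lower from compound 1 to compound 4 (within the scatter).

The compounds shown leave open whether an amine or a methoxy group on this carbon, or a longer chain before the amide carbonyl, would keep this level of growth inhibition. Nothing measured here offers an explanation for these steps.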